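This account rests on a few compounds, and the source may have more. Where it says the series, first, only, none or still open, it means among the compounds named here.

Measured so far in a functional assay on MOLT-4 cells (Homo sapiens) for inhibition, read by sulforhodamine B assay, with a stated time of 48 h, tested at 10 uM; on this read-out lower numbers stand for less inhibition and higher numbers for more inhibition at the one concentration tested (going by the name of the read-out):
compound 1, `c1ccc(-c2cn3ccnc3c(-c3ccc4ncn(C5CCCCC5)c4c3)n2)cc1`: 67.7%
compound 2, `c1ccc2c(-c3cn4ccnc4c(-c4ccc5ncn(C6CCCCC6)c5c4)n3)cccc2c1`: 44.7%

Within the data shown here, compound 2 holds the lowest of the two numbers; the single measured step, a number 23 percentage points lower from compound 1 to compound 2 (beyond the scatter), separates it from compound 1, and that gap lies beyond the scatter.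

Compound 3, `Fc1ccc(-c2cn3ccnc3c(-c3ccc4ncn(C5CCCCC5)c4c3)n2)cc1`, is not yet measured. Its change from compound 2 is 4-fluorophenyl in place of naphthalen-1-yl on an aromatic carbon. Among the measured compounds shown here, the one step that bears on it is a number 23 percentage points lower from compound 1 to compound 2 (beyond the scatter), which runs the opposite way: phenyl gave way to naphthalen-1-yl and inhibition fell modestly. Compound 3 undoes that, restoring a single six-membered aromatic ring of carbon only, now carrying one fluorine, so a rise back toward the number of compound 1 is expected in this assay, estimated as a number 19.3 percentage points higher from compound 2 to compound 3 (beyond the scatter). What the added fluorine itself contributes cannot be read from two compounds. Compound 3 is therefore estimated at 64%, in the range 47% to 80%.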

Compound 3, a percentage reported as inhibition, at one concentration (the size of the read-out at that concentration, not a potency): 25.2%
Compound 3: middle estimate off by 38.8 percentage points, on the high side, and the stated range ends above it.
By their numbers in this assay, from the lowest: compound 3; then compound 2; then compound 1.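

In this assay, among these compounds, a single added fluorine on the phenyl group at this position lowers the number: fluoro in place of hydrogen gives the largest change so far (a number 42.5 percentage points lower from compound 1 to compound 3 (beyond the scatter)). Replacing naphthalen-1-yl with the smaller 4-fluorophenyl also lowers the number (a number 19.5 percentage points lower from compound 2 to compound 3 (beyond the scatter)), so among these three groups, having one six-membered aromatic ring rather than two does not by itself keep the number high, and compound 1 and compound 3 mark the two ends of the order. Nothing measured here accounts for this result.

Whether the loss is specific to fluoro or to its place on the ring remains open, with 3-fluorophenyl and 2-fluorophenyl untested among the compounds shown. As far as these compounds go, how chloro, methoxy or an amine on the phenyl ring would compare also remains open.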